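Replacing the nitro group: solubility notes on compound 4

The compounds below may be only part of what the source reports. "The series", "measured", "known", "first", "only" and "open" are said of these compounds alone.

Measured so far:
Compound 1 `CCc1ccc(-c2nc3c(c(C)nn3-c3ccccc3)c(-c3ccccc3[N+](=O)[O-])c2C#N)cc1` gives 1200 nM in a physicochemical assay for solubility, read by spectrophotometry, in phosphate buffer, with a stated time of 18 h, at pH 7.4; a higher number here means a more soluble compound, a lower number a less soluble compound.
Compound 2 `CCc1ccc(-c2nc3c(c(C)nn3-c3ccccc3)c(-c3ccccc3C#N)c2C#N)cc1` gives 2400 nM in this assay.
Compound 3 `CCc1ccc(-c2nc3c(c(C)nn3-c3ccccc3)c(-c3ccccc3F)c2C#N)cc1` gives 1700 nM in this assay.

The three compounds share one core and differ only in the group on one aromatic carbon. Compound 1, carrying the nitro group, has the smallest of the three numbers, but it cannot be separated from the others: the step of a 2.0-fold higher number from compound 1 to compound 2 (0.30 log units; within the scatter) and the step of a 1.4-fold higher number from compound 1 to compound 3 (0.15 log units; within the scatter) are both within the scatter, as is the step of a 1.4-fold lower number from compound 2 to compound 3 (0.15 log units; within the scatter).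

Compound 4 `C#Cc1ccccc1-c1c(C#N)c(-c2ccc(CC)cc2)nc2c1c(C)nn2-c1ccccc1` is the next variation at the same position: ethynyl in place of nitro on an aromatic carbon. Among the measured compounds shown here, the steps that bear on it are the two exchanges of the nitro group already measured, from compound 1 to compound 2 and from compound 1 to compound 3; neither moved the number beyond the scatter. For the measured compounds named here, no ethynyl-bearing compound has been measured, so there is no direct precedent. On this basis the expected step is a 1.3-fold higher number from compound 1 to compound 4 (0.10 log units; within the scatter), that is, nothing beyond the scatter in either direction. Compound 4 is therefore estimated at 1500 nM, with a range from 600 nM to 4000 nM.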

Compound 4, solubility: 46000 nM
Compound 4: middle estimate off by 31-fold (1.49 log units), on the low side; the measured number lies above the stated range.
By their numbers in this assay, from the lowest: compounds 1, 3 and 2 (each within the scatter of the next); then compound 4.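

In this assay, among the compounds shown here, this position proves far less flat than the earlier compounds suggested: ethynyl stands apart from all three other groups, with a 38-fold higher number from compound 1 to compound 4 (1.58 log units; beyond the scatter), a 27-fold higher number from compound 3 to compound 4 (1.43 log units; beyond the scatter) and a 19-fold higher number from compound 2 to compound 4 (1.28 log units; beyond the scatter), whereas nitro, cyano and fluoro could not be told apart. A single exchange on this aromatic carbon can therefore move the number well beyond the scatter, and among these four compounds only compound 4 separates from the rest. Nothing available accounts for this separation.

As far as these compounds go, it remains open whether the effect is particular to ethynyl or also appears with other groups at this place, such as a propynyl chain, an amine or a carboxylic acid. From the compounds shown here alone, it is equally open whether the exchange gives a step of similar size when the ethyl group elsewhere on the shared core is replaced by a methoxy group.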